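Azabicyclic pyridyl ethers: aryl to methyl on the oxygen

The source may hold more compounds than are shown below. What is called first, only, known or untested is meant among the compounds shown, and "the series" means these compounds.

Measured compounds:
compound 1 `Clc1ccc(Oc2cncc(C3=CC4CNCC(C3)C4)c2)cc1`: 1.9 nM
compound 2 `COc1cc(C2=CC3CNCC(C2)C3)cnc1Cl`: 0.4 nM
compound 3 `Clc1cccc(Oc2cncc(C3=CC4CNCC(C3)C4)c2)c1`: 1 nM

In an in vitro assay on SH-EP1 cells for displacement of a labelled ligand from Neuronal acetylcholine receptor; alpha4/beta2 (Homo sapiens) (on this read-out lower numbers stand for stronger inhibition and higher numbers for weaker inhibition), compound 3 gives 1 nM and stands second highest of the three numbers. Its nearest neighbour is compound 1, which gives 1.9 nM; the step of a 1.9-fold lower number from compound 1 to compound 3 (0.28 log units; within the scatter) changes only where the chlorine sits on the aryl ether and lies within the scatter. Going by the values given here, compound 2 gives 0.4 nM; no single-place step connects it to compound 3, and its oxygen already carries a methyl, though on a differently substituted core.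

Compound 4 `COc1cncc(C2=CC3CNCC(C2)C3)c1` differs from compound 3 by methyl in place of 3-chlorophenyl on an oxygen on an aromatic ring. Among the compounds with values here, no measured step removes an aryl group from that oxygen, so the only pointer is compound 2, whose methoxy-bearing core gives 0.4 nM, close to the others. The measured step between compound 1 and compound 3 bears on the change only in showing that the aryl ether tolerates variation without leaving the scatter.

Compound 4 is therefore expected to stay close to compound 3, with a step of a 1.5-fold higher number from compound 3 to compound 4 (0.18 log units; within the scatter), and its value in this assay is estimated at 1.5 nM, ranging from 0.4 nM to 6 nM.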

Compound 4, inhibition constant: 0.3 nM
Compound 4: middle estimate off by 5.0-fold (0.70 log units), on the high side; the measured number lies below the stated range.
By their numbers in this assay, from the lowest: compounds 4 and 2 (each within the scatter of the next); then compounds 3 and 1 (each within the scatter of the next).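

In this assay the oxygen on the aromatic ring does not need an aryl group: methyl in place of 3-chlorophenyl gives a 3.3-fold lower number from compound 3 to compound 4 (0.52 log units; beyond the scatter) and methyl in place of 4-chlorophenyl gives a 6.3-fold lower number from compound 1 to compound 4 (0.80 log units; beyond the scatter) on the same core. Both steps lie beyond the scatter and run toward stronger inhibition, whereas the earlier pair showed only that moving the chlorine around the aryl ring stays within the scatter. With methyl on the oxygen, hydrogen in place of chloro on an aromatic carbon gives a 1.3-fold lower number from compound 2 to compound 4 (0.12 log units; within the scatter) and stays within the scatter, so this pair shows no measurable need for that chloro.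

As far as these compounds go, whether ethyl, a longer chain or an aminoethyl group on the oxygen would hold these low numbers remains open. The data at hand offer no measurement that accounts for the steps.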